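A few compounds are considered here, and "the series" means these few. Any claim that something is new, unique, unknown or untested is made for them only; others in the source may bear on it.

Among the compounds with values here, in a functional assay on MDA-MB-435 cells (Homo sapiens) for inhibition (a lower number here means a stronger inhibitor of growth, a higher number a weaker inhibitor of growth), compound 1 (`COc1ccc(-n2cnnc2-c2cc(OC)c(OC)c(OC)c2)cc1`) gives 234 nM as the only true number so far. Compound 2 (`COc1cc(-c2nncn2-c2ccc(N(C)C)cc2)cc(OC)c1OC`) gives > 10 nM as its reading, which is a limit of the assay and not a number. The step (a step that the limit leaves unreadable from compound 1 to compound 2) is the only measured one, and it concerns a different group, so it offers no size to carry over. Compound 3 (`COc1ccc(-n2cnnc2-c2cc(OC)c(OC)c(OC)c2)cc1O`) keeps the core of compound 1 and makes one change (hydroxy in place of hydrogen on an aromatic carbon) on the ring that carries the methoxy group. The new hydroxy sits ortho to that methoxy group and brings a hydrogen-bond donor. Within the data shown here, no measured step covers this change, so the expectation rests on the structure alone and stays loose. The expected step (a 20-fold lower number from compound 1 to compound 3 (1.29 log units; beyond the scatter)) points towards stronger inhibition of growth, well beyond the scatter. Compound 3 is expected at 12 nM (estimated range 1.5 nM to 120 nM).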

Compound 3, concentration for 50% growth inhibition: 24.6 nM
Estimate against measurement, compound 3: 2.1-fold (0.31 log units) below, within the range that was stated.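

In this assay, hydroxy in place of hydrogen gives a 9.5-fold lower number from compound 1 to compound 3 (0.98 log units; beyond the scatter) and so moves the number towards stronger inhibition of growth, beyond the scatter. Within the data shown here, this is the first readable size for any change, and it belongs to a site that no earlier compound had touched: the aromatic carbon ortho to the methoxy group. A single added oxygen atom at this position is therefore enough to shift the reading clearly, and the shift is towards stronger inhibition, not weaker.

Going by these compounds, whether the gain is specific to hydroxy stays open, since an amine or a fluorine on the same carbon would be needed to show it. Compound 2 adds no size to this picture, as its step cannot be read and its reading is a limit of the assay, not a number: the limit of > 10 nM in this assay, at which 1 of the 3 values shown sits.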